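Fluoro Substitution on the Anilide Ring of Compound 1

A few compounds are considered here, and "the series" means these few. Any claim that something is new, unique, unknown or untested is made for them only; others in the source may bear on it.

Measured compounds:
Compound 1, `Cc1cc(=O)n(-c2ccccc2C(F)(F)F)nc1C(=O)Nc1ccc(Oc2ncnc3ccsc23)cc1`, gives 9230 nM.
Compound 2, `Cc1cc(=O)n(-c2ccc(F)cc2)nc1C(=O)Nc1ccc(Oc2ncnc3ccsc23)cc1`, gives 2110 nM.
Compound 3, `Cc1cc(=O)n(-c2ccc(F)c(F)c2)nc1C(=O)Nc1ccc(Oc2ncnc3ccsc23)cc1`, gives 9230 nM.

All three were tested in a functional assay on HepG2 cells (Homo sapiens) for cytotoxicity, read by MTT assay, with a stated time of 72 h; a higher number here means a weaker inhibitor, a lower number a stronger inhibitor. The step of a 4.4-fold lower number from compound 1 to compound 2 (0.64 log units; beyond the scatter) is the only one beyond the scatter that separates compound 1 from another compound; the pair compound 1 and compound 3 shows no change at the digits printed from compound 1 to compound 3 (within the scatter). Within the shared core, compound 2 and compound 3 differ by fluoro in place of hydrogen on an aromatic carbon, and that change made the step of a 4.4-fold higher number from compound 2 to compound 3 (0.64 log units; beyond the scatter).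

The unmeasured compound 4, `Cc1cc(=O)n(-c2ccccc2C(F)(F)F)nc1C(=O)Nc1ccc(Oc2ncnc3ccsc23)c(F)c1`, differs from compound 1 by fluoro in place of hydrogen on an aromatic carbon. Among the measured compounds shown here, this is the same kind of change as the one from compound 2 to compound 3, but not the same: in compound 3 the entering fluoro sits ortho to a fluoro group, whereas in compound 4 it sits ortho to a large group. The cores of compound 1 and compound 2 also differ, by 2-(trifluoromethyl)phenyl in place of 4-fluorophenyl on an aromatic nitrogen, so the earlier step was measured on a different core.

Given that compound 1 already stands at 9230 nM, and that the only precedent for adding a fluoro is a 4.4-fold higher number from compound 2 to compound 3 (0.64 log units; beyond the scatter) on another ring and another core, the step from compound 1 to compound 4 is expected to be small and uncertain, about a 1.3-fold higher number from compound 1 to compound 4 (0.11 log units; within the scatter). Compound 4 is estimated at 12000 nM, with an expected range from 4000 nM to 40000 nM.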

Compound 4, half-maximal inhibitory concentration: 9380 nM
Beside the measured number, compound 4's estimate is 1.3-fold (0.11 log units) above it; measured number inside the range.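

In this assay, fluoro in place of hydrogen on an aromatic carbon gave a 1.0-fold higher number from compound 1 to compound 4 (0.01 log units; within the scatter), so on the core of compound 1 this change leaves no mark that can be told from the scatter. Set beside the earlier case, the same kind of change did not carry over from one core to the other with the same size, and the two steps differ by more than their scatter: the same change on two cores in this assay, a 4.4-fold higher number (0.64 log units; beyond the scatter) from compound 2 to compound 3 and a 1.0-fold higher number (0.01 log units; within the scatter) from compound 1 to compound 4, 4.3-fold (0.63 log units) apart, beyond the scatter of two such steps This does not show that the core alone sets the size of the step, since the fluoro enters a different ring in each pair and the other core differs as well, so the part played by the core cannot be separated from that of the ring, and one pair on each core gives no rule for the series.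

The compounds shown leave open whether fluoro on the same ring of the core of compound 2 would give a step like the one seen on compound 1, which would separate the two explanations. They also leave open whether a chloro or a methoxy group entering the place taken by fluoro in compound 4 would move the number at all.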